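From Isopentylamino to Allylamino on a Shared Core

A few compounds are considered here, and "the series" means these few. Any claim that something is new, unique, unknown or untested is made for them only; others in the source may bear on it.

Compound 2 `CC(C)CCNc1c(O)cc(O)c2c(=O)cc(-c3ccccc3)oc12` was tested in an ADME assay on Hippocampus (Mus musculus), read by MTT assay (a lower number here means that less compound is tolerated, a higher number that more compound is tolerated), where compound 2 gives 12 uM. Compound 1 `CCCNc1c(O)cc2oc(-c3ccccc3)cc(=O)c2c1O` gives 10 uM in this assay, and the two numbers lie within the usual scatter of each other, so compound 2 does not stand apart from compound 1. Compound 3 `C=CCNc1c(O)cc(O)c2c(=O)cc(-c3ccccc3)oc12` has not yet been measured; it differs from compound 2 by vinyl in place of isobutyl on a saturated chain carbon bound to a nitrogen on an aromatic ring. Among the measured compounds shown here, no measured pair shows a change of this kind, so nothing sets its size. The step from compound 2 to compound 3 is expected to be a 1.1-fold lower number from compound 2 to compound 3 (0.04 log units; within the scatter), nothing beyond the scatter. Compound 3 is therefore estimated at 11 uM, between 5 uM and 25 uM.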

Compound 3, half-maximal toxic concentration: 18 uM
For compound 3 the middle estimate is 1.6-fold (0.21 log units) below the measured one; the range from low to high includes it.
By their numbers in this assay, from the lowest: compounds 1, 2 and 3 (each within the scatter of the next).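

In this assay, among the compounds shown here, isopentylamino gives way to allylamino in a 1.5-fold higher number from compound 2 to compound 3 (0.18 log units; within the scatter) and this is the first step measured at this position on the shared core. Vinyl in place of isobutyl, on a saturated chain carbon bound to a nitrogen on an aromatic ring, therefore leaves the number within the scatter, even with a shorter chain and a double bond added. Nothing available explains this result.

Going by these compounds, whether a benzyl group or a chain ending in an amine would move the number beyond the scatter remains open. A single pair also cannot show whether the same change behaves alike on another core.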